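This account rests on a few compounds, and the source may have more. Where it says the series, first, only, none or still open, it means among the compounds named here.

In an assay on CHO cells for displacement of a labelled ligand from adenosine receptor A2b (Homo sapiens), read by scintillation counting, with a stated time of 75 min, in the presence of a further agent that is not named here (on this read-out lower numbers stand for stronger inhibition and higher numbers for weaker inhibition), compound 1 `CCCn1c(=O)[nH]c2nc(-c3ccc(S(=O)(=O)N4CCN(c5ccc(Cl)cc5F)CC4)cc3)[nH]c2c1=O` gives 1.91 nM, compound 2 `CCCn1c(=O)[nH]c2nc(-c3ccc(S(=O)(=O)N4CCN(c5ccccc5C)CC4)cc3)[nH]c2c1=O` gives 0.432 nM, and compound 3 `CCCn1c(=O)[nH]c2nc(-c3ccc(S(=O)(=O)N4CCN(Cc5cccc(Br)c5)CC4)cc3)[nH]c2c1=O` gives 0.148 nM, the lowest number of the three. Compound 4 `CCCn1c(=O)[nH]c2nc(-c3ccc(S(=O)(=O)N4CCN(c5ccc(C)cc5)CC4)cc3)[nH]c2c1=O` differs from compound 3 by 4-methylphenyl in place of 3-bromobenzyl on an amine nitrogen in a ring. Within the data shown here, the steps that bear on this are a 13-fold lower number from compound 1 to compound 3 (1.11 log units; beyond the scatter) and a 2.9-fold lower number from compound 2 to compound 3 (0.47 log units; beyond the scatter): in both, replacing a 4-chloro-2-fluorophenyl or 2-methylphenyl group on the amine nitrogen in a ring with 3-bromobenzyl gave a lower number. The change to compound 4 runs the other way, returning to a substituted phenyl on that nitrogen, so a modestly higher number than compound 3 is expected, near the value of compound 2. For compound 4 the expected value is 0.5 nM (range 0.2 nM to 1.5 nM), an estimated step of a 3.4-fold higher number from compound 3 to compound 4 (0.53 log units; beyond the scatter).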

Compound 4, inhibition constant: 0.706 nM
The estimate for compound 4 lay 1.4-fold (0.15 log units) below the measured number; the measured number falls inside the stated range.
By their numbers in this assay, from the lowest: compound 3; then compounds 2 and 4 (each within the scatter of the next); then compound 1.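

In this assay, with 4-methylphenyl in place of 2-methylphenyl on the amine nitrogen in a ring, the step is a 1.6-fold higher number from compound 2 to compound 4 (0.21 log units; within the scatter), so these two methylphenyl groups are not told apart. 4-Methylphenyl in place of 4-chloro-2-fluorophenyl gives a 2.7-fold lower number from compound 1 to compound 4 (0.43 log units; beyond the scatter). The third phenyl-bearing comparison, 4-methylphenyl in place of 3-bromobenzyl, gives a 4.8-fold higher number from compound 3 to compound 4 (0.68 log units; beyond the scatter), leaving 3-bromobenzyl with the lowest number of the series.

Nothing at hand accounts for these steps. Plain benzyl and 3-methylbenzyl would separate the contribution of the benzyl group from that of the bromine, and that split remains open.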